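Sulfonamide series: secondary methoxybenzylamine in place of tertiary amine

The compounds below may be only part of what the source reports. "The series", "measured", "known", "first", "only" and "open" are said of these compounds alone.

Measured compounds:
compound 1 `COc1ccc(CNCCCNS(=O)(=O)c2cc(C(F)(F)F)cc(C(F)(F)F)c2)cc1OC` — 3500 nM
compound 2 `CN(CCCNS(=O)(=O)c1cc(C(F)(F)F)cc(C(F)(F)F)c1)Cc1ccccc1` — 30000 nM

In a functional assay on HPAC cells (Homo sapiens) for inhibition, read by MTT assay, with a stated time of 72 h (a higher number here means a weaker inhibitor of growth, a lower number a stronger inhibitor of growth), compound 1 gives 3500 nM, while compound 2 gives 30000 nM. Compound 2 thus stands with the higher of the two numbers, and its gap to compound 1 lies beyond the scatter. Compound 3 `COc1ccc(CNCCCNS(=O)(=O)c2cc(C(F)(F)F)cc(C(F)(F)F)c2)cc1` differs from compound 2 by (4-methoxybenzyl)amino in place of benzyl(methyl)amino on a saturated chain carbon, three bonds along the chain from a sulfonamide nitrogen. Among the measured compounds shown here, no measured pair isolates this change, so its size is not known from the data. Compound 3 does share with compound 1 the hydrogen-bond donor on the chain nitrogen and a methoxy-bearing benzyl group, and compound 1 sits at 3500 nM, so a move toward that number is expected rather than none beyond the scatter. The step from compound 2 is estimated as a 5.0-fold lower number from compound 2 to compound 3 (0.70 log units; beyond the scatter). For compound 3 in this assay the estimate is 6000 nM, with a range from 2000 nM to 20000 nM.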

Compound 3, concentration for 50% growth inhibition: 3000 nM
Beside the measured number, compound 3's estimate is 2.0-fold (0.30 log units) above it, and the stated range covers the measured number.
By their numbers in this assay, from the lowest: compounds 3 and 1 (each within the scatter of the next); then compound 2.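

In this assay the change to (4-methoxybenzyl)amino on a saturated chain carbon, three bonds along the chain from a sulfonamide nitrogen, gives a 10-fold lower number from compound 2 to compound 3 (1.00 log units; beyond the scatter) and so puts a measured size on this change at this position. Hydrogen in place of methoxy on an aromatic carbon gives a 1.2-fold lower number from compound 1 to compound 3 (0.07 log units; within the scatter) and shows that the extra methoxy of compound 1 adds nothing that can be read here. No supporting data bear on why either step has its size.

The step to compound 3 alters the methyl on the chain nitrogen and the methoxy on the benzyl group together, and the compounds shown do not separate these two parts. From the compounds shown here alone, a plain benzylamino group would separate them, while the effect of a longer chain remains open as well.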